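The source may hold more compounds than are shown below. What is called first, only, known or untested is meant among the compounds shown, and "the series" means these compounds.

Measured so far in an ADME assay (liver) for metabolic stability, with Liver microsome (Homo sapiens) as the target, using microsomes and NADPH, with a stated time of 30 min, tested at 1 uM; a higher number here means faster removal of the compound, a lower number slower removal:
- compound 1 `Nc1ccc(S(=O)(=O)N2CCN(c3ncc(C(O)(C(F)(F)F)C(F)(F)F)cc3C3CC3)CC2)cn1`: 38 mL.min-1.g-1
- compound 2 `CC(C)(O)C#Cc1cc(C(O)(C(F)(F)F)C(F)(F)F)cnc1N1CCN(S(=O)(=O)c2ccc(N)nc2)CC1`: < 14 mL.min-1.g-1, a limit of the assay and not a number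

The position of compound 2 is therefore known only as a limit, (the limit of < 14 mL.min-1.g-1 in this assay, at which 1 of the 2 values shown sits).

Compound 3 `CC(C)(C)n1cc(-c2cc(C(O)(C(F)(F)F)C(F)(F)F)cnc2N2CCN(S(=O)(=O)c3ccc(N)nc3)CC2)cn1` differs from compound 2 by one change: 1-(tert-butyl)-1H-pyrazol-4-yl in place of 3-hydroxy-3-methylbut-1-yn-1-yl on an aromatic carbon. The 1-(tert-butyl)-1H-pyrazol-4-yl group enters on an aromatic carbon, ortho to a large group and two atoms from the ring nitrogen.

Within the data shown here, one measured step bears on this place: an at least 2.7-fold lower number from compound 1 to compound 2 (0.43 log units; beyond the scatter), on going from cyclopropyl to 3-hydroxy-3-methylbut-1-yn-1-yl. Compound 3 gives up that alkynyl group again, so a modest rise in this assay is expected, of similar size to that step but opposite in direction, and resting on this single step. The expected change is an at least 2.1-fold higher number from compound 2 to compound 3 (0.33 log units; beyond the scatter).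

For compound 3 the estimated value is 30 mL.min-1.g-1, with an expected range of 14 mL.min-1.g-1 to 65 mL.min-1.g-1.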

Compound 3, intrinsic clearance in microsomes: 86 mL.min-1.g-1
Beside the measured number, compound 3's estimate is 2.9-fold (0.46 log units) below it, and the stated range ends below it.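

In this assay, this place on an aromatic carbon, ortho to a large group and two atoms from the ring nitrogen, responds strongly to the group it carries: 1-(tert-butyl)-1H-pyrazol-4-yl in place of 3-hydroxy-3-methylbut-1-yn-1-yl gives an at least 6.1-fold higher number from compound 2 to compound 3 (0.78 log units; beyond the scatter). Leaving the alkynyl group does not simply return the number to that of the cyclopropyl analogue, since 1-(tert-butyl)-1H-pyrazol-4-yl in place of cyclopropyl gives a 2.3-fold higher number from compound 1 to compound 3 (0.35 log units; beyond the scatter), which places the pyrazole highest of the three groups shown. Compound 2 stands at a limit of the assay and not at a number, so its step has no upper end: the limit of < 14 mL.min-1.g-1 in this assay, at which 1 of the 3 values shown sits.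

The compounds shown do not separate the triple bond from the hydroxy group in 3-hydroxy-3-methylbut-1-yn-1-yl, nor the tert-butyl group from the pyrazole ring. A saturated hydroxyalkyl chain, or a pyrazole carrying a methyl group in place of tert-butyl, would address those two questions.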